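A Second Chloro Added to Compound 3

This account rests on a few compounds, and the source may have more. Where it says the series, first, only, none or still open, it means among the compounds named here.

Three compounds have been measured in a functional assay on A549 cells (Homo sapiens) for cytotoxicity, read by MTT assay, with a stated time of 48 h; on this read-out higher numbers stand for an effect only at larger amounts of compound and lower numbers for an effect already at smaller amounts:

Compound 1, `Cc1c(O)c(=O)ccn1CC(=O)N/N=C1\C(=O)N(CC(=O)Nc2ccc(Cl)cc2)c2ccccc21`, gives 28300 nM.
Compound 2, `Cc1ccc(NC(=O)CN2C(=O)/C(=N\NC(=O)Cn3ccc(=O)c(O)c3C)c3ccccc32)cc1`, gives 47500 nM.
Compound 3, `Cc1c(O)c(=O)ccn1CC(=O)N/N=C1\C(=O)N(CC(=O)Nc2cccc(Cl)c2)c2ccccc21`, gives 28000 nM.

Compound 3 has the lowest of the three numbers, but its neighbours sit close: the step of a 1.0-fold lower number from compound 1 to compound 3 (0.00 log units; within the scatter) and the step of a 1.7-fold lower number from compound 2 to compound 3 (0.23 log units; within the scatter) are both within the scatter, so no ranking among the three can be claimed.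

Compound 4, `Cc1c(O)c(=O)ccn1CC(=O)N/N=C1\C(=O)N(CC(=O)Nc2cc(Cl)cc(Cl)c2)c2ccccc21`, is the next compound to be measured in this assay. It differs from compound 3 by chloro in place of hydrogen on an aromatic carbon.

Within the data shown here, two measured steps bear on this change. The step of a 1.7-fold higher number from compound 1 to compound 2 (0.22 log units; within the scatter) shows that exchanging chloro for methyl on the aryl amide changed nothing beyond the scatter, and the step of a 1.0-fold lower number from compound 1 to compound 3 (0.00 log units; within the scatter) shows that moving the chloro from one position of that ring to another was equally without effect. Among the measured compounds shown here, no measured pair adds a second chloro to a ring already carrying one, so a direct precedent is lacking. On the evidence of these steps, the move from compound 3 to compound 4 is expected to lie within the scatter, a 1.1-fold lower number from compound 3 to compound 4 (0.05 log units; within the scatter). Compound 4 is therefore estimated at 25000 nM, with a range from 11000 nM to 56000 nM.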

Compound 4, half-maximal effective concentration: 22100 nM
Beside the measured number, compound 4's estimate is 1.1-fold (0.05 log units) above it; the range from low to high includes it.
By their numbers in this assay, from the lowest: compounds 4, 3, 1 and 2 (each within the scatter of the next, the first and the last beyond it).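

Among these compounds, a second chloro on the aryl amide, meta to the first chloro, makes the 3,5-dichlorophenyl group, and this is the first measured step that adds an atom to this ring rather than exchanging or moving a group. In this assay the addition stays within the scatter (a 1.3-fold lower number from compound 3 to compound 4 (0.10 log units; within the scatter)), and the comparison with the 4-chlorophenyl group does too (a 1.3-fold lower number from compound 1 to compound 4 (0.11 log units; within the scatter)), so this position accepts the extra chloro without a change that can be claimed. The new compound does give the first step in the series beyond the scatter, a modest one against the 4-methylphenyl group (a 2.1-fold lower number from compound 2 to compound 4 (0.33 log units; beyond the scatter)), but no measurement shown here accounts for it.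

The compounds shown leave open whether an amine, a carboxylic acid or a methoxy group in place of the second chloro would move the number in this assay beyond the scatter. From the compounds shown here alone, it also remains open whether a bromo or a trifluoromethyl group at this position would widen the modest gap to the 4-methylphenyl compound or leave the number where it stands.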